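Swapping the aryl group on the triazole of compound 3

This account rests on a few compounds, and the source may have more. Where it says the series, first, only, none or still open, it means among the compounds named here.

The shared core of compound 3 `N#CC1=C(N)Oc2c(N)cc3nc4ccccc4nc3c2C12C(=O)N(Cc1cnnn1-c1cccc(C(F)(F)F)c1)c1ccccc12` carries a five-membered aromatic ring with three nitrogens, and on one of those nitrogens sits a 3-(trifluoromethyl)phenyl group. For the measured compounds named here, in a functional assay on HepG2 cells (Homo sapiens) for antiproliferative activity, read by MTT assay, with a stated time of 48 h (a higher number here means a weaker inhibitor, a lower number a stronger inhibitor), compound 3 gives 15800 nM, the only actual number among the three measured compounds. Compound 1 `N#CC1=C(N)Oc2c(c3nc4ccccc4nc3c3ccccc23)C12C(=O)N(Cc1cnnn1-c1ccc(N)cc1)c1ccccc12` reaches only a limit of the assay, > 50000 nM. Compound 2 `Cc1cc(C)cc(-n2nncc2CN2C(=O)C3(C(C#N)=C(N)Oc4c3c3nc5ccccc5nc3c3ccccc43)c3ccccc32)c1` likewise stops at a limit, > 50000 nM. Going by the values given here, because of the limit of > 50000 nM in this assay, at which 2 of the 3 values shown sit, the step that the two limits leave unreadable from compound 1 to compound 2 cannot be read, so no measured step tells how changing the group on that aromatic nitrogen moves potency. Compound 4 `COc1cc(-n2nncc2CN2C(=O)C3(C(C#N)=C(N)Oc4c(N)cc5nc6ccccc6nc5c43)c3ccccc32)c(OC)cc1Cl` differs from compound 3 only there: 4-chloro-2,5-dimethoxyphenyl in place of 3-(trifluoromethyl)phenyl on an aromatic nitrogen. With no readable step to lean on, the expectation is that a 1.1-fold lower number from compound 3 to compound 4 (0.02 log units; within the scatter) stays within the usual scatter, in no particular direction. Compound 4 is therefore estimated at 15000 nM, with a range from 5000 nM to 50000 nM.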

Compound 4, half-maximal inhibitory concentration: > 50000 nM
Compound 4: no number, only a limit (the forecaster's own chance of this, stated with the estimate: 30%); middle value at least 3.3-fold (0.52 log units) from the limit.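

In this assay, 4-chloro-2,5-dimethoxyphenyl in place of 3-(trifluoromethyl)phenyl gives an at least 3.1-fold higher number from compound 3 to compound 4 (0.50 log units; beyond the scatter). For the compounds shown here, this is the first readable sign that the group on this aromatic nitrogen matters for potency, and here the entering group gives the weaker result. The reading for compound 4 is a limit and not a number, so the full size of this step stays unknown, and the other steps between limits still cannot be read: the limit of > 50000 nM in this assay, at which 3 of the 4 values shown sit.

Going by these compounds alone, the single pair does not separate the parts of the entering group, so the roles of its chlorine and its two methoxy groups remain open. As far as these compounds go, it is also open whether a plain phenyl group or a 3-methoxyphenyl group on this nitrogen would stay near compound 3 or fall away as compound 4 does.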